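The source may hold more compounds than are shown below. What is called first, only, known or untested is meant among the compounds shown, and "the series" means these compounds.

Working notes on a shared core carrying an aryl amine on one side and a five-membered aromatic ring on the other. Compound 1 `Fc1cccc(F)c1Nc1nccc(-c2cccnc2)n1` gives 21000 nM in a functional assay for inhibition, with Homo sapiens as the target; on this read-out lower numbers stand for stronger inhibition and higher numbers for weaker inhibition. Compound 2 `Cc1ccsc1-c1ccnc(Nc2ccc(N(C)C)cc2)n1` gives 1800 nM in this assay. Compound 3 `Cc1cccc(Nc2nccc(-c3ccc[nH]3)n2)c1` gives 8500 nM in this assay and stands second highest of the three numbers: its nearest neighbour is compound 1, a higher number beyond the scatter, and its furthest is compound 2, a lower number beyond the scatter. Within the data shown here, no two measured compounds differ in one place, so no single step can be read off directly.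

Compound 4 `Cc1cccc(Nc2nccc(-c3ccc(C)s3)n2)c1` is the open question. Relative to compound 3 the change is 5-methylthiophen-2-yl in place of 1H-pyrrol-2-yl on an aromatic carbon.

Among the measured compounds shown here, compound 3 is the only measured compound whose ring on the core carries a hydrogen-bond donor. Compound 2 also carries a five-membered aromatic ring bearing sulfur on the same core and gives 1800 nM, but it differs from compound 4 at the aryl amine as well, so that number is only a loose guide. The expected step is a 2.8-fold lower number from compound 3 to compound 4 (0.45 log units; beyond the scatter), toward a lower number and beyond the scatter though modest. Compound 4 is estimated at 3000 nM in this assay, with an expected range from 800 nM to 12000 nM.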

Compound 4, half-maximal inhibitory concentration: 1400 nM
Estimate against measurement, compound 4: 2.1-fold (0.33 log units) above; low and high end bracket the measured number.
By their numbers in this assay, from the lowest: compounds 4 and 2 (each within the scatter of the next); then compound 3; then compound 1.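

With the aryl amine held fixed, this position on an aromatic carbon of the shared core now gives a step that can be read: in this assay, 5-methylthiophen-2-yl in place of 1H-pyrrol-2-yl gives a 6.1-fold lower number from compound 3 to compound 4 (0.78 log units; beyond the scatter) and this lies beyond the scatter. The number at this position therefore depends on which five-membered aromatic ring sits there, and the hydrogen-bond donor of 1H-pyrrol-2-yl can be lost here without the number rising. The change replaces the ring nitrogen with sulfur, removes the donor and adds a methyl all at once, and nothing measured on these compounds bears on why the number falls or how the step divides among these parts.

Still open, as far as these compounds go, is how a thiophen-2-yl without the methyl or a 1-methylpyrrol-2-yl would stand against compound 3 and compound 4, since either would separate the methyl from the exchange of ring. Also open, from the compounds shown here alone, are whether the step carries over to the aryl amines of compound 1 and compound 2, and how a longer chain, an amine or a carboxylic acid in place of the methyl would read.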